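This account rests on a few compounds, and the source may have more. Where it says the series, first, only, none or still open, it means among the compounds named here.

Values measured so far in an ADME assay on BJ cells (Homo sapiens) for cytotoxicity, read by CellTiter-Glo, with a stated time of 72 h; on this read-out lower numbers stand for an effect already at smaller amounts and higher numbers for an effect only at larger amounts of compound

- compound 1 `CC1=C2CC(C)(C)[C@@H]3C=C(OC3)/C(C)=C\C3=C[C@H](C)C[C@]3(O2)C1=O` gives 26000 nM
- compound 2 `CC(=O)O[C@H]1/C=C/C(C)(C)CC2=C(C)[C@@H](OC(C)=O)[C@]3(C[C@@H](C)C=C3/C=C\1C)O2` gives 26000 nM
- compound 3 `COc1ccc(/C2=C\C(=O)/C(C)=C\C3=C[C@H](C)C[C@@]34OC(=C(C)C4=O)CC2(C)C)cc1` gives 26000 nM

Compound 3 stands level with compound 1 and compound 2 at the digits shown, so the three readings show no spread. No two of these measured compounds differ in only one place, so the series offers no direct measure of a single substitution.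

The next compound is compound 4 `CC1=C2CC(C)(C)/C(c3ccc(C(F)(F)F)cc3)=C/C(=O)/C(C)=C\C3=C[C@H](C)C[C@]3(O2)C1=O`, which keeps the core of compound 3 and has trifluoromethyl in place of methoxy on an aromatic carbon, para to a large group (trifluoromethyl in place of methoxy on an aromatic carbon). Cut one bond further out, the same difference reads 4-methoxyphenyl to 4-(trifluoromethyl)phenyl.

Compound 1 and compound 2 carry no 4-methoxyphenyl, yet they read the same as compound 3 at 26000 nM in this assay on the numbers available. That gives no basis for expecting a shift in either direction. The estimated change no change at the digits printed from compound 3 to compound 4 (within the scatter) is expected to stay within the scatter. In this assay the expected value for compound 4 is 26000 nM (estimated range 13000 nM to 35000 nM).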

Compound 4, half-maximal effective concentration: 26000 nM
Compound 4: the middle estimate sits on the measured number at the digits printed, and the stated range covers the measured number.
By their numbers in this assay, from the lowest: compounds 1, 2, 3 and 4 (each within the scatter of the next).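

In this assay, the series now has its first comparison that differs in one place only: trifluoromethyl in place of methoxy on an aromatic carbon, para to a large group, gives no change at the digits printed from compound 3 to compound 4 (within the scatter). Within the data shown here, at this position, therefore, the reading does not separate a group of 2 heavy atoms with 1 hydrogen-bond acceptor from a group of 4 heavy atoms with 0 hydrogen-bond acceptors, a direct result that the earlier compounds, which differ from one another in more than one place, could not provide. Among these compounds, no supporting measurement is available to explain this flat step, and the result covers only this one pair of substituents on the shared core.

Still open, from the compounds shown here alone, is whether an amine, a carboxylic acid or a longer alkoxy chain at the same position would give a reading beyond the scatter, or whether this position stays flat across a wider range of groups. Among the compounds shown here, also open is the contribution of any single structural difference among compound 1, compound 2 and compound 3, since no one-place step connects these compounds.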